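A few compounds are considered here, and "the series" means these few. Any claim that something is new, unique, unknown or untested is made for them only; others in the source may bear on it.

Measured compounds:
compound 1 `CC(C)OC(=O)N1CCC(Oc2ncnc3c2CCN3c2ccc(C#N)cc2F)CC1` — 134%
compound 2 `CC(C)OC(=O)N1CCC(Oc2ncnc3c2CCN3c2ccc(C#N)c(F)c2)CC1` — 121%
compound 3 `CC(C)OC(=O)N1CCC(Oc2ncnc3c2CCN3c2ccc([S+]([O-])N(C)C)cc2)CC1` — 128%

In a functional assay on CHO-K1 cells with Glucose-dependent insulinotropic receptor (Homo sapiens) as the target, read by a luciferase reporter, with a stated time of 5 h (a higher number here means a larger maximal response, a lower number a smaller maximal response), compound 3 sits between compound 1 and compound 2, and both of those gaps fall within the scatter, so the three values are effectively level. Compound 4 `CSc1ccc(N2CCc3c(OC4CCN(C(=O)OC(C)C)CC4)ncnc32)cc1F` is the next member. It differs from compound 3 at the aryl group on the ring nitrogen: a group of 9 heavy atoms (7 carbon, 1 fluorine, 1 sulfur; one six-membered aromatic ring of carbon only) in place of a group of 11 heavy atoms (8 carbon, 1 nitrogen, 1 oxygen, 1 sulfur; one six-membered aromatic ring of carbon only), on a nitrogen on an aromatic ring in a ring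

For the measured compounds named here, the steps that bear on this are the earlier exchanges at the same place, a number 6 percentage points lower from compound 1 to compound 3 (within the scatter) and a number 7 percentage points higher from compound 2 to compound 3 (within the scatter), neither beyond the scatter. Going by the values given here, the one step beyond the scatter, a number 13 percentage points lower from compound 1 to compound 2 (beyond the scatter), concerned the two fluorinated nitrile groups only. A step of no more than the scatter is therefore expected for compound 4, with a number 3 percentage points lower from compound 3 to compound 4 (within the scatter) as the estimated change. Compound 4 is estimated at 125%, range 105% to 145%.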

Compound 4, largest response reached (reported as percent of maximum), in percent of the reference or control that the assay uses: 121%
Estimate against measurement, compound 4: 4 percentage points above; the range from low to high includes it.
By their numbers in this assay, from the lowest: compounds 2, 4, 3 and 1 (each within the scatter of the next, the first and the last beyond it).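

In this assay, methylsulfanyl in place of cyano on an aromatic carbon gives no change at the digits printed from compound 2 to compound 4 (within the scatter) and so holds the maximal response level with the nitrile at this position. The exchange on the ring nitrogen gives a number 7 percentage points lower from compound 3 to compound 4 (within the scatter) and, with a number 13 percentage points lower from compound 1 to compound 4 (beyond the scatter) as the other step, compound 1 stands apart from compound 4 just as it does from compound 2. No measured evidence bears on these steps.
Open, from the compounds shown here alone, is how an amine or a carboxylic acid in place of methylsulfanyl on that aromatic carbon would read.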